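Removing the isopropyl group from an aromatic ether oxygen

A few compounds are considered here, and "the series" means these few. Any claim that something is new, unique, unknown or untested is made for them only; others in the source may bear on it.

Three compounds have been measured in a functional assay on DLD-1 cells (Homo sapiens) for cytotoxicity, with a stated time of 48 h; on this read-out higher numbers stand for weaker inhibition and lower numbers for stronger inhibition:

Compound 1 `CCOc1ccc2oc(/C=C/[S+](C)[O-])cc(=O)c2c1` gives 4900 nM
Compound 2 `CC(C)CCOc1ccc2oc(/C=C/[S+](C)[O-])cc(=O)c2c1` gives 4100 nM
Compound 3 `CC(C)Oc1ccc2oc(/C=C/[S+](C)[O-])cc(=O)c2c1` gives 8000 nM

For the measured compounds named here, compound 3 carries the highest of the three numbers, but its distances to the other two are small: a 1.6-fold higher number from compound 1 to compound 3 (0.21 log units; within the scatter) and a 2.0-fold higher number from compound 2 to compound 3 (0.29 log units; within the scatter) both lie within the scatter, so no compound of the three can be called stronger or weaker than another. The same holds for a 1.2-fold lower number from compound 1 to compound 2 (0.08 log units; within the scatter).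

Compound 4 `C[S+]([O-])/C=C/c1cc(=O)c2cc(O)ccc2o1` differs from compound 3 in one place: hydrogen in place of isopropyl on an oxygen on an aromatic ring. The three measured steps all change what sits on that same oxygen, swapping one saturated chain for another, and every one of them stayed within the scatter. None of them, however, removes the chain altogether and leaves a free hydroxyl, so the step to compound 4 reaches outside what has been tried. On the evidence of the three steps, the expected step in this assay is none beyond the scatter, though with more uncertainty than a plain exchange of chains would carry. Compound 4 is therefore estimated at 9000 nM, with a range from 3000 nM to 27000 nM, meaning an expected step of a 1.1-fold higher number from compound 3 to compound 4 (0.05 log units; within the scatter).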

Compound 4, half-maximal inhibitory concentration: > 10000 nM
Compound 4: no number, only a limit; the forecaster's own chance of this, stated with the estimate: 10%; middle value at least 1.1-fold (0.04 log units) from the limit.
By their numbers in this assay, from the lowest: compounds 2, 1 and 3 (each within the scatter of the next). At a limit, above all of these: compound 4.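

In this assay compound 4 is recorded only as a limit of the assay, not as a number: the limit of > 10000 nM in this assay, at which 1 of the 4 values shown sits.

Even so, replacing a chain on this oxygen with hydrogen produces the first separation at this position that can be read beyond the scatter, an at least 2.4-fold higher number from compound 2 to compound 4 (0.38 log units; beyond the scatter), so the free hydroxy form gives weaker inhibition than the isopentyl ether. The other two steps, an at least 1.2-fold higher number from compound 3 to compound 4 (0.09 log units; that floor lies within the scatter) and an at least 2.0-fold higher number from compound 1 to compound 4 (0.30 log units; that floor lies within the scatter), have floors within the scatter, so these comparisons with the isopropyl and ethyl ethers show no firm separation, although the true gaps may be larger than these floors.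

From the compounds shown here alone, the size of the drop on losing the chain stays unknown while compound 4 has no number, and a single free hydroxy compound cannot show whether the hydroxy group itself or the absence of a chain matters here. It also remains open where a methyl ether, a benzyl ether or an amine in place of the ether oxygen would fall in this assay, and whether any of them would separate from the three ethers shown.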